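Fluoro Removal in Acetoxy Trifluorobenzoic Acid Series

A few compounds are considered here, and "the series" means these few. Any claim that something is new, unique, unknown or untested is made for them only; others in the source may bear on it.

Measured so far:
compound 1 `O=C(O)c1cc(F)c(F)c(F)c1O` — 66%
compound 2 `CC(=O)Oc1c(F)c(F)c(F)c(F)c1C(=O)O` — 80%

Two compounds have numbers in a toxicity assay on the whole organism (strain CD-1) for cytotoxicity, with Mus musculus as the target, with a stated time of 14 days, at a dose of 150 mg/kg by the intraperitoneal route; on this read-out lower numbers stand for a stronger effect and higher numbers for a weaker effect at the one dose given. Compound 1 gives 66% and compound 2 gives 80%. Among these two, compound 2 stands highest; its nearest neighbour is compound 1, whose number sits lower by a gap that lies beyond the scatter, so on this read-out compound 2 shows the weaker effect of the pair. Within the data shown here, no pair that differs in a single place has been measured, so no step size is established so far.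

Compound 3 `CC(=O)Oc1c(C(=O)O)cc(F)c(F)c1F` has not yet been measured in this assay. It departs from compound 2 as follows: hydrogen in place of fluoro on an aromatic carbon. Among the measured compounds shown here, with only two measured numbers and no step to rest on, the expected size of the step from compound 2 to compound 3 is small, likely within the scatter, with any drift leaning toward the lower number of compound 1 because compound 1 gives 66% with the same pattern of three fluoro groups. The estimated step is a number 6 percentage points lower from compound 2 to compound 3 (within the scatter). Compound 3 is expected to give 74%, within a range of 60% to 88%.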

Compound 3, a percentage reported as activity, at one dose (the size of the read-out at that dose, not a potency): 70%
Compound 3: the middle estimate sits 4 percentage points above what was measured; low and high end bracket the measured number.
By their numbers in this assay, from the lowest: compounds 1, 3 and 2 (each within the scatter of the next, the first and the last beyond it).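

Working notes on the position ortho to a carboxy group: in this assay, hydrogen in place of fluoro gives a number 10 percentage points lower from compound 2 to compound 3 (within the scatter), the first step read at this position, and at this size the read-out does not separate the two atoms there. Acetyl in place of hydrogen on the oxygen on the aromatic ring gives a number 4 percentage points higher from compound 1 to compound 3 (within the scatter), so this change on the three-fluoro pattern also stays inside the scatter, and each single change around compound 3 is small on this read-out. No supporting measurement bears on either step, so neither can be tied to an underlying cause.

The compounds shown leave open whether a chloro, a methoxy or an amine at this same position would read apart from fluoro and hydrogen, and whether hydrogen in place of fluoro at any of the other fluoro positions would give a step of similar size. Also open, going by these compounds, is whether a longer acyl chain, such as propionyl or butyryl, on the oxygen would stay within the scatter of compound 3.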